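A Methyl Ester in Place of the Hydroxyphenyl Amide

This account rests on a few compounds, and the source may have more. Where it says the series, first, only, none or still open, it means among the compounds named here.

Compound 2 `CC1=C(/C=C/C(C)=C/C=C/C(C)=C/C(=O)Nc2ccc(O)cc2)C(C)(C)CCC1n1ccnc1` is a long chain of alternating double bonds ending in an amide to a hydroxyphenyl group. Within the data shown here, in a functional assay on MCF7 cells for inhibition of cytochrome P450 26A1 (Homo sapiens) (a lower number here means a stronger inhibitor, a higher number a weaker inhibitor), compound 2 gives 56 nM, the only number known here. Compound 1 `CC1=C(/C=C/C(C)=C/C=C/C(C)=C\C(=O)Nc2ccc(O)cc2)C(C)(C)CCC1n1ccnc1` is its near twin; the fact that one of compounds 1 and 2 is drawn with a defined configuration and the other without, at the place where they differ marks the single place where the two drawings part, and for compound 1 the result in this assay is "not determined" (no result reported). Compound 3 `COC(=O)/C=C(C)/C=C/C=C(C)/C=C/C1=C(C)C(n2ccnc2)CCC1(C)C` keeps the whole chain and the shared core of compound 2 but changes the end group: methoxy in place of (4-hydroxyphenyl)amino on a carbonyl carbon. Among the measured compounds shown here, whether that exchange helps or hurts is untested, since no measured pair here spans it. The expectation is a loss of potency, moderate but beyond the usual scatter, so that compound 3 is estimated at 150 nM, within 30 nM to 800 nM. That expected shift, a 2.7-fold higher number from compound 2 to compound 3 (0.43 log units; beyond the scatter), is an estimate only.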

Compound 3, half-maximal inhibitory concentration: 200 nM
Compound 3: the middle estimate sits 1.3-fold (0.12 log units) below what was measured, and the stated range covers the measured number.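

In this assay, among these compounds, methoxy in place of (4-hydroxyphenyl)amino on the carbonyl carbon gives a 3.6-fold higher number from compound 2 to compound 3 (0.55 log units; beyond the scatter) and is the first measured change at this end of the molecule. The end group therefore affects the read-out, yet the aromatic ring is not required for inhibition: compound 3 has no ring and no hydrogen-bond donors in that group, and it still gives 200 nM as its result. Nothing measured here speaks to why the number rises.

The change removes the whole end group at once, which leaves open how much of the step belongs to the ring, the hydroxyl or the amide hydrogen. Phenylamino, ethoxy or a carboxylic acid at the same carbonyl carbon would each separate these parts further.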